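The source may report more compounds than this note shows. Statements on the series, on what has been measured and on what is new or still open speak of the compounds shown alone.

Compound 1 `COc1ccn2c(-c3ccc(NC(=O)c4ccc([N+](=O)[O-])o4)cc3C)cnc2c1` and compound 2 `COc1ccn2c(-c3ccc(NC(=O)c4ccc([N+](=O)[O-])o4)cc3OC)cnc2c1` share a core and differ in a single place: methoxy in place of methyl on an aromatic carbon. In a functional assay on MGC-803 cells (Homo sapiens) for antiproliferative activity, read by CCK-8 assay, with a stated time of 72 h (on this read-out lower numbers stand for stronger inhibition and higher numbers for weaker inhibition), compound 1 gives 1030 nM. For compound 2 the result is not a number but a limit of the assay, > 20000 nM. That value is the limit of > 20000 nM in this assay, at which 1 of the 3 values shown sits. The measured step is therefore an at least 19-fold higher number from compound 1 to compound 2 (1.28 log units; beyond the scatter), a large step in the direction of weaker inhibition.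

Compound 3 `COc1ccn2c(-c3ccc(NC(=O)c4ccc([N+](=O)[O-])o4)c(C)c3)cnc2c1` is built from the same atoms as compound 1, joined differently; the difference between the two cores is not broken down here. In this assay compound 3 gives 1380 nM, a value that sits within the scatter of the value of compound 1.

Compound 4 `COc1ccn2c(-c3ccc(NC(=O)c4ccc([N+](=O)[O-])o4)c(OC)c3)cnc2c1` has not yet been measured. It stands to compound 3 exactly as compound 2 stands to compound 1: methoxy in place of methyl on an aromatic carbon. The surroundings of the changed position read the same in both pairs, so this is the same change made a second time. Because an at least 19-fold higher number from compound 1 to compound 2 (1.28 log units; beyond the scatter) ran to a limit, the step of a 14-fold higher number from compound 3 to compound 4 (1.16 log units; beyond the scatter) is expected to be of similar size. Compound 4 is accordingly estimated at 20000 nM, between 6000 nM and 60000 nM, with a real chance that only a limit and no number is returned.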

Compound 4, half-maximal inhibitory concentration: 7520 nM
Estimate against measurement, compound 4: 2.7-fold (0.42 log units) above; measured number inside the range.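

On both cores, methoxy in place of methyl moves the result in the same direction, towards weaker inhibition, and in this assay the new pair shows a 5.4-fold higher number from compound 3 to compound 4 (0.74 log units; beyond the scatter). So the direction of the change carries over from the core of compound 1 to the core of compound 3, but its size does not, as the two steps are set apart beyond what scatter would explain: the same change on two cores in this assay, an at least 19-fold higher number (1.28 log units; beyond the scatter) from compound 1 to compound 2 and a 5.4-fold higher number (0.74 log units; beyond the scatter) from compound 3 to compound 4, at least 3.5-fold (0.55 log units) apart, beyond the scatter of two such steps.

As far as these compounds go, compound 2 gives > 20000 nM, which is a limit of the assay and not a number, so the true size of the first step and of the gap between the two steps remains unknown. Nor do two pairs establish a rule for other cores, and these results do not show why the same change costs a different amount on each core.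

From the compounds shown here alone, it remains open how a fluorine, a hydroxyl group, an amine or a longer chain such as ethoxy would behave in place of the methyl on either core. Going by these compounds, it is also open whether the loss on going from methyl to methoxy would appear again on a third core.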